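Acid to cyclopropane carboxamide on the shared core

The source may report more compounds than this note shows. Statements on the series, on what has been measured and on what is new or still open speak of the compounds shown alone.

Compound 1 `Cc1nc(-c2ccc(C(F)(F)F)cc2)sc1CNc1ccc(C(=O)O)cc1` is known in a functional assay on CHO cells for agonist activity at Free fatty acid receptor 1 (Homo sapiens) (a lower number here means that less compound is needed, a higher number that more compound is needed for the effect), only as a limit: compound 1 gives < 10000 nM, which is a limit of the assay (the limit of < 10000 nM in this assay, at which 1 of the 3 values shown sits). Compound 4 `Cc1nc(-c2ccc(C(F)(F)F)cc2)sc1CNc1ccc([C@H]2C[C@@H]2C(N)=O)cc1` differs from it by 2-carbamoylcyclopropyl in place of carboxy on an aromatic carbon. Within the data shown here, the only measured guide comes from a different core: compound 2 `CC(CC(=O)O)c1ccc(NCc2cccc(Oc3ccccc3)c2)cc1` gives 126 nM in this assay, compound 3 `CNC(=O)CCc1ccc(NCc2cccc(Oc3ccccc3)c2)cc1` gives 49 nM, and the exchange of an acid for an amide there gave a 2.6-fold lower number from compound 2 to compound 3 (0.41 log units; beyond the scatter). That step is modest, and here a three-membered non-aromatic ring enters as well, so the direction is expected to be toward a lower number while the size remains uncertain. Compound 4 is expected at 200 nM, within 30 nM to 2000 nM. Because compound 1 has only the limit < 10000 nM, the expected step that the limit leaves unreadable from compound 1 to compound 4 can be judged only against that limit.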

Compound 4, half-maximal effective concentration: 4.47 nM
Compound 4: the middle estimate sits 45-fold (1.65 log units) above what was measured; measured number outside the range, below it.
By their numbers in this assay, from the lowest: compound 4; then compound 3; then compound 2.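

The step from compound 1 to compound 4 cannot be read: in this assay compound 1 gives < 10000 nM as a limit of the assay. The compounds shown leave open what the amide and the three-membered non-aromatic ring of 2-carbamoylcyclopropyl each contribute on the shared core.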